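This account rests on a few compounds, and the source may have more. Where it says the series, first, only, none or still open, it means among the compounds named here.

Measured so far:
- Compound 1 `CC(C)[C@H](NC(=O)COc1cccc2ccccc12)C(=O)N[C@@H](CC(=O)O)C(=O)COc1ccccc1[N+](=O)[O-]`: 27700 nM
- Compound 2 `CC(C)[C@H](NC(=O)COc1cccc2ccccc12)C(=O)N[C@@H](CC(=O)O)C(=O)COc1cc(F)cc(F)c1`: 15900 nM

In a functional assay with Homo sapiens as the target (on this read-out higher numbers stand for weaker inhibition and lower numbers for stronger inhibition), compound 2 gives 15900 nM, which lies within the usual scatter of compound 1 at 27700 nM. Among the compounds with values here, with only two values, neither compound can be ranked above the other.

Compound 3 `CC(C)[C@H](NC(=O)COc1cccc2ccccc12)C(=O)N[C@@H](CC(=O)O)C(=O)COc1cc(F)cc(F)c1F` differs from compound 2 in one place: fluoro in place of hydrogen on an aromatic carbon, (fluoro in place of hydrogen on an aromatic carbon), which turns 3,5-difluorophenyl into 2,3,5-trifluorophenyl.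

Within the data shown here, the only measured step that bears on this is a 1.7-fold lower number from compound 1 to compound 2 (0.24 log units; within the scatter), where 3,5-difluorophenyl replaced 2-nitrophenyl. Even that exchange of a whole group stayed within the scatter, so a single added fluoro is not expected to move this assay beyond the scatter, in either direction. The expected change is a 1.2-fold lower number from compound 2 to compound 3 (0.09 log units; within the scatter). For compound 3 the estimated value is 13000 nM, with an expected range from 5000 nM to 32000 nM.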

Compound 3, half-maximal inhibitory concentration: 11200 nM
Compound 3: the middle estimate sits 1.2-fold (0.06 log units) above what was measured; measured number inside the range.
By their numbers in this assay, from the lowest: compounds 3, 2 and 1 (each within the scatter of the next, the first and the last beyond it).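

In this assay, placing a fluoro in place of hydrogen on this aromatic carbon, ortho to a fluoro group and to a large group and para to a fluoro group, gives a 1.4-fold lower number from compound 2 to compound 3 (0.15 log units; within the scatter), so this single addition cannot be told apart from repeat-measurement noise. Within the data shown here, the exchange of the whole group does separate two compounds for the first time, with a 2.5-fold lower number from compound 1 to compound 3 (0.39 log units; beyond the scatter), a modest step that 3,5-difluorophenyl did not achieve on its own. No supporting measurement is available to explain either step.

As far as these compounds go, it remains open whether a methyl, a methoxy or an amine at this ring carbon would move the number beyond the scatter. From the compounds shown here alone, the effect of replacing the carboxylic acid elsewhere on the shared core also remains open.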